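Amino in Place of Aminomethyl: Expected Cytotoxicity Step

A few compounds are considered here, and "the series" means these few. Any claim that something is new, unique, unknown or untested is made for them only; others in the source may bear on it.

In an ADME assay on L929 cells (Mus musculus) for cytotoxicity, read by resazurin assay, with a stated time of 72 h (on this read-out higher numbers stand for weaker inhibition and lower numbers for stronger inhibition), compound 3 `NCc1ccc(C(=O)c2ccn(-c3ccc4c(c3)B(O)OC4)c2)cc1` gives only a limit, > 10 ug/mL. Compound 1 `O=C(c1ccc(Cl)cc1)c1ccn(-c2ccc3c(c2)B(O)OC3)c1` likewise gives a limit in this assay, > 10 ug/mL. Compound 2 `O=C(c1ccc(O)cc1)c1ccn(-c2ccc3c(c2)B(O)OC3)c1` also gives a limit in this assay, > 10 ug/mL. All three values sit at the limit of > 10 ug/mL in this assay, at which 3 of the 3 values shown sit, so the steps a step that the two limits leave unreadable from compound 1 to compound 2, a step that the two limits leave unreadable from compound 1 to compound 3 and a step that the two limits leave unreadable from compound 2 to compound 3 cannot be sized; they show only that exchanging chloro, hydroxy and aminomethyl on this aromatic carbon left the read-out at the limit in every case.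

Compound 4 `Nc1ccc(C(=O)c2ccn(-c3ccc4c(c3)B(O)OC4)c2)cc1` differs from compound 3 in one place: amino in place of aminomethyl on an aromatic carbon. Among the compounds with values here, no measured step involves an amino group, and none of the measured steps has a readable size, so the only guidance is that the three exchanges at this position gave no measurable cytotoxicity. The step that the limit leaves unreadable from compound 3 to compound 4 is therefore expected to be no step beyond the scatter, with the read-out most likely staying at the limit. Compound 4 is estimated at 30 ug/mL in this assay, with a range from 10 ug/mL to 100 ug/mL.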

Compound 4, half-maximal inhibitory concentration: 3.9 ug/mL
Compound 4: the middle estimate sits 7.7-fold (0.89 log units) above what was measured; the whole stated range lies above it.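

In this assay this position proves able to change the read-out: of the four groups shown on this aromatic carbon, only amino brings the number off the limit, with an at least 2.5-fold lower number from compound 3 to compound 4 (0.40 log units; beyond the scatter), an at least 2.5-fold lower number from compound 2 to compound 4 (0.40 log units; beyond the scatter) and an at least 2.5-fold lower number from compound 1 to compound 4 (0.40 log units; beyond the scatter). The earlier compounds shown here gave no sign of this, since chloro, hydroxy and aminomethyl all left the read-out at the limit. The three new steps are lower bounds only, because their starting compounds rest at a limit: the limit of > 10 ug/mL in this assay, at which 3 of the 4 values shown sit.

The steps among compound 1, compound 2 and compound 3 cannot be read, so any differences among those three stay hidden. Also open, going by these compounds, is whether a dimethylamino group or an acetamido group on this carbon would lower the number as amino does.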